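A few compounds are considered here, and "the series" means these few. Any claim that something is new, unique, unknown or untested is made for them only; others in the source may bear on it.

Measured so far, in a functional assay on FM3A cells (Mus musculus) for antiproliferative activity, read by cell counting, with a stated time of 2 days; a higher number here means a weaker inhibitor, a lower number a stronger inhibitor:

- compound 1, `COc1cccc(C(=O)c2sc(Nc3ccccc3)nc2N)c1`: 6200 nM
- compound 2, `COc1cc(C(=O)c2sc(Nc3ccc(C)cc3)nc2N)cc(OC)c1OC`: 15 nM
- compound 3, `COc1ccc(C(=O)c2sc(Nc3ccc(Cl)cc3)nc2N)cc1`: > 10000 nM

For compound 3 the value is a limit of this assay, not a number; the line the limit of > 10000 nM in this assay, at which 1 of the 3 values shown sits, records it. Compound 2 gives the lowest of the two numbers available, and its nearest neighbour is compound 1 with a far higher number, a gap well beyond the scatter. Going by the values given here, no two of the measured compounds differ in one place only, so no measured step is available to guide the next change.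

Compound 4, `COc1cc(C(=O)c2sc(Nc3ccc(Cl)cc3)nc2N)cc(OC)c1OC`, differs from compound 2 in a single spot: chloro in place of methyl on an aromatic carbon. The 4-methylphenyl group becomes a 4-chlorophenyl group while the rest of the shared core, including the trimethoxy-bearing ring, stays as in compound 2. A small step is expected, if any, leaning toward a slightly higher number. For compound 4 the expected value in this assay is 40 nM, with a likely range from 10 nM to 300 nM, and the step from compound 2 is expected to be a 2.7-fold higher number from compound 2 to compound 4 (0.43 log units; beyond the scatter).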

Compound 4, half-maximal inhibitory concentration: 420 nM
Beside the measured number, compound 4's estimate is 11-fold (1.02 log units) below it; the measured number lies above the stated range.
By their numbers in this assay, from the lowest: compound 2; then compound 4; then compound 1. At a limit, above all of these: compound 3.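

In this assay, the exchange of methyl for chloro on the aromatic ring, with the rest of the shared core unchanged, gives a 28-fold higher number from compound 2 to compound 4 (1.45 log units; beyond the scatter). Going by these compounds alone, this is the first measured single-place change here, and it shows that this spot is sensitive: the two groups each count one heavy atom, no ring and no net charge, yet they are far from interchangeable. Nothing measured here gives a reason for a step of this size.

Still open, as far as these compounds go, is how other groups at this spot would compare, such as a fluoro, an ethyl or an amine, and whether the order depends on the group's size or on something else. From the compounds shown here alone, it is also open whether the same exchange would cost as much with a different pattern of methoxy groups on the other ring.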